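Vero cell tolerance across the series

The compounds below may be only part of what the source reports. "The series", "measured", "known", "first", "only" and "open" are said of these compounds alone.

compound 1 `COC(=O)c1cc(-c2cccc(NC(=O)c3ccc(/C=C/C(=O)c4cccc(Cl)c4)cc3)c2)on1`: > 2.5 ug/mL
compound 2 `COC(=O)c1cc(-c2cccc(NC(=O)c3ccc(/C=C/C(=O)c4cccnc4)cc3)c2)on1`: "not determined" (no result reported)
compound 3 `CC(C)Cc1ccc(C(=O)/C=C/c2ccc(C(=O)O)cc2)cc1`: < 10 ug/mL

In an ADME assay on Vero cells (Chlorocebus sabaeus) for cytotoxicity, read by MTT assay, with a stated time of 72 h (a higher number here means that more compound is tolerated, a lower number that less compound is tolerated), compound 1 gives > 2.5 ug/mL, which is a limit of the assay rather than a number. Compound 3 gives < 10 ug/mL in this assay, also a limit. Compound 2 carries no number in this assay, its entry being "not determined" (no result reported). Compound 4 `COC(=O)c1cc(-c2cccc(NC(=O)c3ccc(/C=C/C(=O)c4ccccc4)cc3)c2)on1` differs from compound 2 in one place: phenyl in place of pyridin-3-yl on a carbonyl carbon. Within the data shown here, with compound 2 unmeasured, no step between measured compounds exists in this assay, so neither size nor direction of the change can be read from the data; the only anchors are the limit of < 10 ug/mL in this assay, at which 1 of the 3 values shown sits, and (the limit of > 2.5 ug/mL in this assay, at which 1 of the 3 values shown sits). Compound 4 is therefore expected in this assay near those limits, at 5 ug/mL, estimated between 2 ug/mL and 15 ug/mL.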

Compound 4, half-maximal cytotoxic concentration: > 50 ug/mL
Compound 4 gave a limit, no number; the forecaster's own chance of this, stated with the estimate: 70%; middle value at least 10-fold (1.00 log units) from the limit.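

Among these compounds, compound 1 and compound 4 both stand at limits of the assay, so no step between them can be read. On these data alone, whether hydrogen in place of chloro on an aromatic carbon shifts tolerance at all remains open.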